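This account rests on a few compounds, and the source may have more. Where it says the series, first, only, none or still open, it means among the compounds named here.

Among the compounds with values here, in a functional assay on SK-OV-3 cells (Homo sapiens) for antiproliferative activity, read by MTT assay, with a stated time of 24 h (on this read-out higher numbers stand for weaker inhibition and lower numbers for stronger inhibition), compound 2 `COc1ccc(C(=O)/C=C/c2ccc([N+](=O)[O-])cc2)c2c1C=CC(C)(C)O2` gives 3420 nM, the only true number so far. Compound 1 `COc1ccc(C(=O)/C=C/c2cccc(F)c2)c2c1C=CC(C)(C)O2` gives > 10000 nM, which is a limit of the assay and not a number. Within the data shown here, the single measured step, an at least 2.9-fold lower number from compound 1 to compound 2 (0.46 log units; beyond the scatter), was taken at the same place on the chain, so it is the one that bears on what follows. That step starts from a limit: the limit of > 10000 nM in this assay, at which 1 of the 2 values shown sits. Compound 3 `COc1ccc(/C=C/C(=O)c2ccc(OC)c3c2OC(C)(C)C=C3)cn1` has 6-methoxypyridin-3-yl in place of 4-nitrophenyl on a double-bonded chain carbon bound to a double-bonded chain carbon. The 4-nitrophenyl group of compound 2 is therefore lost, and a modest shift toward weaker inhibition in this assay is expected. The expected change is a 1.8-fold higher number from compound 2 to compound 3 (0.24 log units; within the scatter). For compound 3 the estimated value is 6000 nM, with an expected range from 2000 nM to 18000 nM.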

Compound 3, half-maximal inhibitory concentration: > 10000 nM
Compound 3 ended at the assay's limit; the forecaster's own chance of this, stated with the estimate: 35%; at least 1.6-fold (0.22 log units) between middle value and limit.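

In this assay, an at least 2.9-fold higher number from compound 2 to compound 3 (0.46 log units; beyond the scatter), so at this place on the chain 6-methoxypyridin-3-yl does not keep the activity seen with 4-nitrophenyl. Of the three groups shown here, 4-nitrophenyl alone gives a true number, and compound 3 now joins compound 1 at a limit of the assay: the limit of > 10000 nM in this assay, at which 2 of the 3 values shown sit. The step between compound 1 and compound 3 cannot be read, since both values are limits, and 3-fluorophenyl and 6-methoxypyridin-3-yl cannot be ordered.

The compounds shown leave open whether the true number depends on the nitro group itself or whether another group on the phenyl ring, such as an amine, a nitrile or a carboxylic acid, would also give one. They also leave open how much stronger inhibition this place on the chain can reach.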